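This account rests on a few compounds, and the source may have more. Where it says the series, first, only, none or still open, it means among the compounds named here.

Of the compounds shown here, three with a shared core have been tested in a toxicity assay on THP-1 cells (Homo sapiens) for inhibition (on this read-out lower numbers stand for higher toxicity in this test and higher numbers for lower toxicity in this test), and they differ only in the group on the carbonyl carbon. Compound 3 `COc1ccc(-c2cnc(NC(=O)c3cccc(F)c3)n2C)cc1` carries 3-fluorophenyl there and gives > 100000 nM, which is a limit of the assay and not a number. Compound 1 `COc1ccc(-c2cnc(NC(=O)c3cnc[nH]3)n2C)cc1`, with 1H-imidazol-5-yl in that place, gives > 100000 nM, again a limit. Compound 2 `COc1ccc(-c2cnc(NC(=O)c3ccc(Br)cc3)n2C)cc1`, with 4-bromophenyl, gives > 100000 nM, also a limit. All the evidence so far is therefore (the limit of > 100000 nM in this assay, at which 3 of the 3 values shown sit).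

Compound 4 `COc1ccc(-c2cnc(NC(=O)C3CCCCC3)n2C)cc1` has cyclohexyl in place of 3-fluorophenyl on a carbonyl carbon, so a non-aromatic ring replaces an aromatic one: cyclohexyl in place of 3-fluorophenyl on a carbonyl carbon.

The changes that bear on this one were made at the same place: a step that the two limits leave unreadable from compound 1 to compound 3, a step that the two limits leave unreadable from compound 2 to compound 3 and a step that the two limits leave unreadable from compound 1 to compound 2. None of them has a size that can be read. Starting from compound 3, no step beyond the scatter is expected in this assay because of the limit of > 100000 nM in this assay, at which 3 of the 3 values shown sit, and no direction can be favoured. The expected step is a number no higher from compound 3 to compound 4 (the limit leaves the size open). Compound 4 is estimated at 100000 nM, with an expected range of 50000 nM to 200000 nM, and the assay will most likely report only a limit again.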

Compound 4, half-maximal cytotoxic concentration: > 100000 nM
Compound 4: no number, only a limit (the forecaster's own chance of this, stated with the estimate: 85%); the middle value sits exactly at the limit.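

Among these compounds, compound 1, compound 2, compound 3 and compound 4 all sit at a limit of the assay rather than at a number, so no step between them can be read in this assay: the limit of > 100000 nM in this assay, at which 4 of the 4 values shown sit. The compounds shown leave open whether changing the group on the carbonyl carbon alters the result in this assay at all, and what actual number any of these four compounds would give.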